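A few compounds are considered here, and "the series" means these few. Any claim that something is new, unique, unknown or untested is made for them only; others in the source may bear on it.

Compound 1 `O=Cc1ccc(-c2cn3ccnc3c(-c3ccc4ncn(C5CCCCC5)c4c3)n2)cc1`: 20.7%
Compound 2 `COc1ccccc1-c1cn2ccnc2c(-c2ccc3ncn(C4CCCCC4)c3c2)n1`: 7.73%
Compound 3 `Fc1ccccc1-c1cn2ccnc2c(-c2ccc3ncn(C4CCCCC4)c3c2)n1`: 10.1%

All three were tested in a functional assay on SN12C cells (Homo sapiens) for inhibition, read by sulforhodamine B assay, with a stated time of 48 h, tested at 10 uM; a higher number here means more inhibition at the concentration tested (going by the name of the read-out), a lower number less inhibition. Compound 3 stands close to compound 2, within the scatter, and the step of a number 10.6 percentage points lower from compound 1 to compound 3 (beyond the scatter) places it beyond the scatter below compound 1. Compound 4 `FC(F)(F)c1cccc(-c2cn3ccnc3c(-c3ccc4ncn(C5CCCCC5)c4c3)n2)c1` differs from compound 3 by 3-(trifluoromethyl)phenyl in place of 2-fluorophenyl on an aromatic carbon. For the measured compounds named here, no measured step matches this change: a number 13 percentage points lower from compound 1 to compound 2 (beyond the scatter) and a number 10.6 percentage points lower from compound 1 to compound 3 (beyond the scatter) both remove the 4-formylphenyl, and a number 2.4 percentage points higher from compound 2 to compound 3 (within the scatter) exchanges fluoro for methoxy on an aromatic carbon, a small move. The expected step of a number 1.9 percentage points higher from compound 3 to compound 4 (within the scatter) in this assay is therefore small, of uncertain direction, and not beyond the scatter. Compound 4 is estimated at 12% in this assay, with a range from 0% to 30%.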

Compound 4, a percentage reported as inhibition, at one concentration (the size of the read-out at that concentration, not a potency): 8.3%
Beside the measured number, compound 4's estimate is 3.7 percentage points above it, and the stated range covers the measured number.
By their numbers in this assay, from the lowest: compounds 2, 4 and 3 (each within the scatter of the next); then compound 1.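

In this assay, a 3-(trifluoromethyl)phenyl group on this aromatic carbon reads like the 2-substituted phenyl groups, with a number 1.8 percentage points lower from compound 3 to compound 4 (within the scatter) and a number 0.6 percentage points higher from compound 2 to compound 4 (within the scatter). Among the four compounds, only the 4-formylphenyl group stands apart, with a number 12.4 percentage points lower from compound 1 to compound 4 (beyond the scatter). Nothing available gives a reason for this result. The compounds shown leave open whether the number of compound 1 goes with the formyl group itself or with its place on the phenyl ring. They also leave open how a phenyl ring carrying an amine or a carboxylic acid would read.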